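Replacing the Ester of Compound 2 with an Amide

The source may hold more compounds than are shown below. What is called first, only, known or untested is meant among the compounds shown, and "the series" means these compounds.

Compound 1 `CCOC(=O)c1oc2ccc(NS(=O)(=O)c3ccc(Cl)cc3)cc2c1C` gives 24300 nM in a functional assay on HCT-116 cells (Homo sapiens) for inhibition, read by MTT assay, with a stated time of 72 h; a lower number here means a stronger inhibitor, a higher number a weaker inhibitor. Compound 2 `CCOC(=O)c1oc2ccc(N(Cc3ccccc3)S(=O)(=O)c3ccc(Cl)cc3)cc2c1C` gives 4860 nM in this assay. Compound 3 `CCOC(=O)c1oc2ccc(N(CC3CCCCC3)S(=O)(=O)c3ccc(Cl)cc3)cc2c1C` gives 14100 nM in this assay.

Compound 2 stands lowest of the three, set apart by a 5.0-fold lower number from compound 1 to compound 2 (0.70 log units; beyond the scatter) and by a 2.9-fold higher number from compound 2 to compound 3 (0.46 log units; beyond the scatter). Compound 4 `Cc1c(C(=O)NCCCn2ccnc2)oc2ccc(N(Cc3ccccc3)S(=O)(=O)c3ccc(Cl)cc3)cc12` differs from compound 2 by (3-(1H-imidazol-1-yl)propyl)amino in place of ethoxy on a carbonyl carbon. Among the measured compounds shown here, all three measured steps concern the sulfonamide nitrogen; none touches the carbonyl carbon, so no step bears directly on this change. With nothing to guide the direction, compound 4 is expected near compound 2, with a 1.0-fold higher number from compound 2 to compound 4 (0.01 log units; within the scatter) as the estimated step and a wide range. For compound 4 the estimate in this assay is 5000 nM, between 1500 nM and 16000 nM.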

Compound 4, half-maximal inhibitory concentration: 17100 nM
Estimate against measurement, compound 4: 3.4-fold (0.53 log units) below; measured number above the stated range.
By their numbers in this assay, from the lowest: compound 2; then compounds 3, 4 and 1 (each within the scatter of the next).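

Among the compounds shown here, this is the first view of the carbonyl carbon, and it shows that the number in this assay responds to a change at this position: (3-(1H-imidazol-1-yl)propyl)amino in place of ethoxy gives a 3.5-fold higher number from compound 2 to compound 4 (0.55 log units; beyond the scatter). The ester-to-amide swap therefore made the inhibitor weaker here, not stronger. Nothing available explains this loss, or shows which part of the larger group matters. Still open, as far as these compounds go, is how a plain ethylamino group, a carboxylic acid or a shorter chain carrying the same ring would behave on this carbon.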